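Trifluoromethoxy in place of fluoro on a shared core

A few compounds are considered here, and "the series" means these few. Any claim that something is new, unique, unknown or untested is made for them only; others in the source may bear on it.

Measured so far:
- compound 1 `Oc1cccc(-c2cc(-c3ccccc3F)cc(-c3ccccc3O)n2)c1` gives 8470 nM in a functional assay on HCT-15 cells (Homo sapiens) for inhibition; on this read-out lower numbers stand for stronger inhibition and higher numbers for weaker inhibition
- compound 2 `Oc1cccc(-c2cc(-c3ccccc3F)cc(-c3cccc(O)c3)n2)c1` gives 5300 nM in this assay
- compound 3 `Oc1cccc(-c2cc(-c3ccc(F)cc3)cc(-c3cccc(O)c3)n2)c1` gives 6310 nM in this assay

Compound 2 shows the lowest of the three numbers, but the others sit close: a 1.6-fold lower number from compound 1 to compound 2 (0.20 log units; within the scatter) and a 1.2-fold higher number from compound 2 to compound 3 (0.08 log units; within the scatter) are both within the scatter, so no ordering among these three compounds can be claimed.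

Compound 4 `Oc1cccc(-c2cc(-c3ccccc3OC(F)(F)F)cc(-c3cccc(O)c3)n2)c1` differs from compound 2 in one place: trifluoromethoxy in place of fluoro on an aromatic carbon. The trifluoromethoxy sits on an aromatic carbon of a six-membered aromatic ring of carbon only, ortho to a large group.

Neither measured step concerns a change of this kind; one moves a hydroxy group and the other moves a fluoro, and both stayed within the scatter. With only small effects seen so far, a step of modest size is expected in this assay, in no firm direction. Compound 4 is therefore estimated at 5000 nM, with a range from 1800 nM to 14000 nM, meaning an expected step of a 1.1-fold lower number from compound 2 to compound 4 (0.03 log units; within the scatter).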

Compound 4, half-maximal inhibitory concentration: 4220 nM
The estimate for compound 4 lay 1.2-fold (0.07 log units) above the measured number; low and high end bracket the measured number.
By their numbers in this assay, from the lowest: compounds 4, 2, 3 and 1 (each within the scatter of the next).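

Earlier steps only moved a hydroxy or a fluoro group around the shared core, whereas this one replaces the group itself, putting trifluoromethoxy, with 5 heavy atoms, where fluoro, with 1, stood. In this assay this gives a 1.3-fold lower number from compound 2 to compound 4 (0.10 log units; within the scatter), so even this much larger group, on an aromatic carbon ortho to a large group, leaves the two compounds indistinguishable. Nothing measured here offers an explanation for how close they stand.

Still open is whether any group at this position can shift the number beyond the scatter, since an amine, a carboxylic acid and a longer chain such as butoxy appear in none of these compounds. It is also unclear whether trifluoromethoxy would behave the same way with 2-hydroxyphenyl in place of 3-hydroxyphenyl.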